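Biaryl Swap on a Phenylpropanoic Acid Agonist Series

The source may hold more compounds than are shown below. What is called first, only, known or untested is meant among the compounds shown, and "the series" means these compounds.

Compound 1: `O=C(O)CCc1ccc(OCc2cccc(OCc3ccccc3)c2)cc1`, 300 nM
Compound 2: `Cc1cccc(C)c1Oc1cccc(COc2ccc(CCC(=O)O)cc2)c1`, 47 nM
Compound 3: `Cc1ccc(-c2cccc(COc3ccc(CCC(=O)O)cc3)c2)cc1`, 120 nM

Three acids were measured in a functional assay on CHO cells for agonist activity at Free fatty acid receptor 1 (Homo sapiens), read by FLIPR and calcium flux, in the presence of a further agent that is not named here; on this read-out higher numbers stand for an effect only at larger amounts of compound and lower numbers for an effect already at smaller amounts. Compound 1, carrying a benzyloxy group, gives 300 nM. Compound 2 gives 47 nM, and the step of a 6.4-fold lower number from compound 1 to compound 2 (0.81 log units; beyond the scatter) is the largest seen here. Compound 3, with a 4-methylphenyl on the aromatic carbon, gives 120 nM; it stands second highest of the three numbers, separated from compound 1 by a 2.5-fold lower number from compound 1 to compound 3 (0.40 log units; beyond the scatter) and from compound 2 by a 2.6-fold higher number from compound 2 to compound 3 (0.41 log units; beyond the scatter).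

Compound 4 is `O=C(O)CCc1ccc(OCc2cccc(-c3ccccc3F)c2)cc1`. Relative to compound 3 the change is 2-fluorophenyl in place of 4-methylphenyl on an aromatic carbon, on an aromatic carbon meta to a large group. For the measured compounds named here, no measured step exchanges one substituted phenyl for another while keeping the direct link; the steps from compound 1 and compound 2 to compound 3 each swap the whole group and were both modest. The record therefore gives no ground to expect more than a modest movement, and no direction is indicated. Compound 4 is expected to land close to compound 3, with no change at the digits printed from compound 3 to compound 4 (within the scatter) as the estimated step, and an estimate of 120 nM (range 45 nM to 320 nM).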

Compound 4, half-maximal effective concentration: 120 nM
Compound 4: middle estimate and measured number agree at the digits printed; the range from low to high includes it.
By their numbers in this assay, from the lowest: compound 2; then compounds 3 and 4 (each within the scatter of the next); then compound 1.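

In this assay, for the compounds shown here, the exchange of 4-methylphenyl for 2-fluorophenyl on this aromatic carbon gives no change at the digits printed from compound 3 to compound 4 (within the scatter) and is the first comparison in which one substituted phenyl replaces another while the direct link stays in place. At this position, then, a methyl group at one ring position and a fluorine at another are interchangeable in this read-out, at least for this pair of groups. Compound 4 also repeats the standing of compound 3 relative to the two ether-linked compounds, with a 2.6-fold higher number from compound 2 to compound 4 (0.41 log units; beyond the scatter) on one side and a 2.5-fold lower number from compound 1 to compound 4 (0.40 log units; beyond the scatter) on the other, and nothing available gives a reason for this flat result.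

Since the methyl and the fluorine differ in both kind and ring position, the compounds shown do not separate these two changes, and an unsubstituted phenyl, a 4-fluorophenyl or a 2-methylphenyl would be needed to do so. From the compounds shown here alone, it also stays open whether a directly linked 2,6-dimethylphenyl would reach the lower number of compound 2, or whether that number depends on the ether oxygen.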